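The source may report more compounds than this note shows. Statements on the series, on what has been measured and on what is new or still open speak of the compounds shown alone.

Series notes, 5-hydroxytryptamine receptor 4 binding.

Three compounds have numbers in an assay on HEK293 cells for displacement of a labelled ligand from 5-hydroxytryptamine receptor 4 (Homo sapiens), read by scintillation counting; a higher number here means a weaker inhibitor, a lower number a stronger inhibitor. Compound 1 `COc1cc(N)c(Cl)cc1C(=O)NC1CCNCC1` gives 1580 nM, and compound 2 `CC(C)n1c(=O)n(C(=O)NC2CCNCC2)c2ccccc21` gives 1580 nM. Among the compounds with values here, compound 3 `COc1cc(N)c(Cl)cc1C(=O)NC1CCN(CCCCCO)CC1` gives 63.1 nM and so stands lowest of the three, with both other compounds well outside the scatter; the one single-point step, a 25-fold lower number from compound 1 to compound 3 (1.40 log units; beyond the scatter), shows that putting a chain on the ring amine nitrogen of compound 1 lowers the number sharply.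

Compound 4 `COc1cc(N)c(Cl)cc1C(=O)NC1CCN(CCCCCCCCS(=O)(=O)O)CC1` keeps the core and the chain of compound 3 and alters only the end of that chain: 3-sulfopropyl in place of hydroxy on a saturated chain carbon, five bonds along the chain from an amine nitrogen in a ring. Within the data shown here, no measured pair in this assay separates a change at the chain end from the presence of the chain itself, so the step from compound 1 to compound 3 only fixes that the chain matters, not how its terminus matters. With nothing in the numbers to anchor the direction, the expected step in this assay is a 1.6-fold higher number from compound 3 to compound 4 (0.20 log units; within the scatter), no change beyond the scatter. Compound 4 is therefore estimated at 100 nM, within 25 nM to 400 nM.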

Compound 4, inhibition constant: 15800 nM
For compound 4 the middle estimate is 160-fold (2.20 log units) below the measured one; measured number above the stated range.
By their numbers in this assay, from the lowest: compound 3; then compounds 1 and 2 (each within the scatter of the next); then compound 4.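

The end of the chain is far from a tolerant place in this assay: 3-sulfopropyl in place of hydroxy gives a 250-fold higher number from compound 3 to compound 4 (2.40 log units; beyond the scatter) and undoes the whole of the earlier gain, a 25-fold lower number from compound 1 to compound 3 (1.40 log units; beyond the scatter). Compound 4 at 15800 nM even stands above compound 1 at 1580 nM in the printed values, so a chain on the ring amine nitrogen does not lower the number whatever its end, and what the chain carries at its terminus counts as much as its presence. No measurement shown bears on the cause of this step.

The change lengthens the chain and replaces the hydroxy at once, and the compounds shown do not separate the two. A longer chain still ending in hydroxy, or a carboxylic acid or an amine at the end of the chain of compound 3, would tell them apart.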